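This account rests on a few compounds, and the source may have more. Where it says the series, first, only, none or still open, it means among the compounds named here.

Measured in a functional assay on MCF7 cells (Homo sapiens) for antiproliferative activity, read by MTT assay, with a stated time of 48 h; on this read-out lower numbers stand for stronger inhibition and higher numbers for weaker inhibition:
Compound 1 `N=C(N)N/N=C(/C=C/c1ccc(Br)cc1)c1ccccc1` 250 nM
Compound 2 `COc1ccc(/C=C/C(=N/NC(=N)N)c2ccccc2)cc1` 14000 nM
Compound 3 `N=C(N)N/N=C(/C=C/c1ccccc1)c1ccc(Cl)cc1` 350 nM

In this assay compound 3 gives 350 nM and so sits within the scatter of compound 1, with compound 2 far higher. Compound 4 `COc1ccc(C(/C=C/c2ccccc2)=N\NC(=N)N)cc1` carries methoxy in place of chloro on an aromatic carbon, para to a large group (methoxy in place of chloro on an aromatic carbon). Going by the values given here, one measured step bears on this: methoxy in place of bromo gave a large change (a 56-fold higher number from compound 1 to compound 2 (1.75 log units; beyond the scatter)), though at a different place on the shared core and from a different halogen. A large rise is therefore expected here too, perhaps a smaller one, as an estimated 17-fold higher number from compound 3 to compound 4 (1.23 log units; beyond the scatter) in this read-out. Compound 4 is expected near 6000 nM with 1200 nM to 25000 nM as its estimated range.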

Compound 4, half-maximal inhibitory concentration: 13000 nM
Compound 4: middle estimate off by 2.2-fold (0.34 log units), on the low side; low and high end bracket the measured number.
By their numbers in this assay, from the lowest: compounds 1 and 3 (each within the scatter of the next); then compounds 4 and 2 (each within the scatter of the next).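

In this assay, methoxy in place of chloro on an aromatic carbon, para to a large group, brings a 37-fold higher number from compound 3 to compound 4 (1.57 log units; beyond the scatter) and so counts as a large step. The earlier large rise, a 56-fold higher number from compound 1 to compound 2 (1.75 log units; beyond the scatter) in the same direction, therefore is not confined to one place on the shared core or to one halogen, and neither pair goes against this. No available evidence accounts for the rise at this position.

As far as these compounds go, what stays open is how a hydroxyl, an amine or a longer alkoxy chain would read at this position, and whether only methoxy gives such high numbers.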